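The compounds below may be only part of what the source reports. "The series", "measured", "known", "first", "only" and "open" are said of these compounds alone.

Compound 1 `COc1ccc(CCCCCC(=O)N2CCOC2=O)cc1`: in an assay on HEK293 cells for inhibition of N-acylethanolamine-hydrolyzing acid amidase (Rattus norvegicus), read by LC-MS, with a stated time of 30 min (a higher number here means a weaker inhibitor, a lower number a stronger inhibitor), compound 1 gives > 20000 nM, which is a limit of the assay.
Compound 2 `O=C(O)c1ccc(CCCCCC(=O)N2CCOC2=O)cc1`: in this assay compound 2 gives > 20000 nM, which is a limit of the assay.
Compound 3 `NC(=O)c1ccc(CCCCCC(=O)N2CCOC2=O)cc1`: in this assay compound 3 gives > 20000 nM, which is a limit of the assay.

Compound 3 therefore stands only at a limit, and the two other values shown sit at the same limit (the limit of > 20000 nM in this assay, at which 3 of the 3 values shown sit). The steps a step that the two limits leave unreadable from compound 1 to compound 2, a step that the two limits leave unreadable from compound 1 to compound 3 and a step that the two limits leave unreadable from compound 2 to compound 3 are all unreadable, since both ends of each are limits.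

Compound 4 `Nc1ccc(CCCCCC(=O)N2CCOC2=O)cc1` differs from compound 3 in one place: amino in place of carbamoyl on an aromatic carbon. Among the measured compounds shown here, no measured step in this assay gives a readable size or direction for this change; the step from compound 2 to compound 3, which also swaps a group in that position, is equally unreadable. With every value at the limit, compound 4 is expected to stay at or near that limit, so the step that the limit leaves unreadable from compound 3 to compound 4 is expected to be none beyond the scatter. Compound 4 is thus estimated at 30000 nM in this assay, within 10000 nM to 100000 nM, most likely reported only as a limit.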

Compound 4, half-maximal inhibitory concentration: 15700 nM
Compound 4: the middle estimate sits 1.9-fold (0.28 log units) above what was measured; the range from low to high includes it.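

Among the values shown in this assay, the amino group, on an aromatic carbon para to a large group, is the first to give a number rather than a limit, with compound 4 at 15700 nM. Amino in place of carbamoyl gives an at least 1.2-fold lower number from compound 3 to compound 4 (0.10 log units; that floor lies within the scatter), amino in place of carboxy gives an at least 1.2-fold lower number from compound 2 to compound 4 (0.10 log units; that floor lies within the scatter), and amino in place of methoxy gives an at least 1.2-fold lower number from compound 1 to compound 4 (0.10 log units; that floor lies within the scatter). Each step is only a floor, so the change is not shown to exceed the scatter, and the other three compounds supply no number to measure it against: the limit of > 20000 nM in this assay, at which 3 of the 4 values shown sit.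

As far as these compounds go, the true sizes of these steps remain open, and the steps among compound 1, compound 2 and compound 3 still cannot be read. Also open, from the compounds shown here alone, is whether a hydroxy group, a dimethylamino group or a longer chain would move the number further.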